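This account rests on a few compounds, and the source may have more. Where it says the series, first, only, none or still open, it means among the compounds named here.

Of the compounds shown here, two sharing one core have been measured so far in a functional assay on SW-620 cells (Homo sapiens) for cytotoxicity, read by colorimetric assay (on this read-out lower numbers stand for stronger inhibition and higher numbers for weaker inhibition), and they are hard to separate. Compound 1 `O=C(NO)c1ccc(CN2C(=O)/C(=C3\Nc4ccccc4\C3=N/O)c3cc(F)ccc32)cc1` carries a fluoro group on an aromatic carbon and gives 20 nM as its result. Compound 2 `Cc1ccc2c(c1)/C(=C1/Nc3ccccc3/C1=N\O)C(=O)N2Cc1ccc(C(=O)NO)cc1` carries a methyl group on that carbon and gives 30 nM as its result. Compound 2 therefore stands within the usual scatter of compound 1. Compound 3 `O=C(NO)c1ccc(CN2C(=O)/C(=C3\Nc4ccccc4\C3=N/O)c3cc(Br)ccc32)cc1` differs from compound 2 by one swap, bromo in place of methyl on an aromatic carbon is the full count. For the measured compounds named here, the one measured step bearing on this swap is a 1.5-fold higher number from compound 1 to compound 2 (0.18 log units; within the scatter) for methyl in place of fluoro on that carbon. Going by the values given here, with only this small step as a guide, no change beyond the scatter is expected in this assay for compound 3. The expected step is a 1.2-fold lower number from compound 2 to compound 3 (0.08 log units; within the scatter) on this estimate. Compound 3 is estimated at 25 nM with an expected range of 10 nM to 60 nM overall.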

Compound 3, half-maximal inhibitory concentration: 70 nM
Compound 3: the middle estimate sits 2.8-fold (0.45 log units) below what was measured; the whole stated range lies below it.
By their numbers in this assay, from the lowest: compounds 1 and 2 (each within the scatter of the next); then compound 3.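

In this assay this aromatic carbon proves not to be indifferent to its group: bromo in place of methyl gives a 2.3-fold higher number from compound 2 to compound 3 (0.37 log units; beyond the scatter) and bromo in place of fluoro gives a 3.5-fold higher number from compound 1 to compound 3 (0.54 log units; beyond the scatter) even though fluoro and methyl could not be told apart. Among these three compounds, compound 3 is therefore the weakest, and exchanging one heavy atom for another at this single place is enough for a modest but real change. Nothing on hand explains why bromo stands apart from the other two groups.

Going by these compounds, how a chloro group, a methoxy group or an amine would fare on this same carbon remains open, so bromo cannot yet be called a lone case or part of a trend. All three compounds also share the rest of the core, leaving open whether the bromo step would hold with a change elsewhere in the molecule.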